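The source may report more compounds than this note shows. Statements on the series, on what has been measured and on what is new or still open speak of the compounds shown alone.

In a functional assay on L1210 cells (Mus musculus) for antiproliferative activity (a lower number here means a stronger inhibitor, a higher number a weaker inhibitor), compound 1 `COc1cc(C(=O)c2sc(-c3ccccc3Cl)cc2N)cc(OC)c1OC` gives 20 nM and compound 2 `COc1cc(C(=O)c2sc(-c3ccc(C)cc3)cc2N)cc(OC)c1OC` gives 18 nM, so compound 2 stands level with compound 1 within the scatter. Compound 3 `COc1cc(C(=O)c2sc(-c3cccs3)cc2N)cc(OC)c1OC` has thiophen-2-yl in place of 4-methylphenyl on an aromatic carbon. Within the data shown here, the only measured step, a 1.1-fold lower number from compound 1 to compound 2 (0.05 log units; within the scatter), exchanges one substituted phenyl for another and stays within the scatter. Among the measured compounds shown here, no measured step brings in thiophen-2-yl. No shift beyond the scatter is therefore expected in this assay. The expected step is a 1.1-fold higher number from compound 2 to compound 3 (0.05 log units; within the scatter). For compound 3 the estimate is 20 nM, with an expected range of 8 nM to 50 nM.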

Compound 3, half-maximal inhibitory concentration: 9.8 nM
Beside the measured number, compound 3's estimate is 2.0-fold (0.31 log units) above it; low and high end bracket the measured number.
By their numbers in this assay, from the lowest: compounds 3, 2 and 1 (each within the scatter of the next, the first and the last beyond it).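

At this place next to the ring sulfur in this assay, a five-membered aromatic ring with 1 hetero atom serves as well as a six-membered one, within the scatter of 4-methylphenyl (a 1.8-fold lower number from compound 2 to compound 3 (0.26 log units; within the scatter)). Against 2-chlorophenyl, the same ring gives the only step so far beyond the scatter, and that step is modest (a 2.0-fold lower number from compound 1 to compound 3 (0.31 log units; beyond the scatter)). No available evidence explains either step. Open, as far as these compounds go, is whether the ring sulfur matters, which furan-2-yl would test, and whether an aminomethyl or carboxylic acid group on thiophen-2-yl would keep these numbers.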